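The source may report more compounds than this note shows. Statements on the series, on what has been measured and on what is new or still open speak of the compounds shown alone.

The measured compounds:
Compound 1, `COc1ccc(-c2c(-c3cc(OC)c(OC)c(OC)c3)ssc2=S)cc1`, in a functional assay on SGC-7901 cells (Homo sapiens) for antiproliferative activity, read by MTT assay, with a stated time of 72 h (on this read-out higher numbers stand for weaker inhibition and lower numbers for stronger inhibition), gives 2350 nM.
Compound 2, `COc1ccc(-c2c(-c3cc(OC)c(OC)c(OC)c3)ssc2=S)cc1[N+](=O)[O-]`, in this assay gives 44700 nM.
Compound 3, `COc1ccc(-c2c(-c3cc(OC)c(OC)c(OC)c3)ssc2=O)cc1`, in this assay reaches only a limit of the assay, > 100000 nM.

Compound 2 differs from compound 1 by a single change, (nitro in place of hydrogen on an aromatic carbon). In this assay this change made a 19-fold higher number from compound 1 to compound 2 (1.28 log units; beyond the scatter), so the nitro weakened the inhibition clearly. How the core of compound 1 differs from the core of compound 3 is not broken down here. Compound 4, `COc1ccc(-c2c(-c3cc(OC)c(OC)c(OC)c3)ssc2=O)cc1[N+](=O)[O-]`, has not yet been measured. It differs from compound 3 by nitro in place of hydrogen on an aromatic carbon, the same change, at the same surroundings, as from compound 1 to compound 2. For compound 3 only a limit is known, and among the three values shown one sits at the limit of > 100000 nM in this assay, at which 1 of the 3 values shown sits. Because of a 19-fold higher number from compound 1 to compound 2 (1.28 log units; beyond the scatter), the same change is expected to weaken the inhibition in the same way here. In this assay the expected step is a step that the limit leaves unreadable from compound 3 to compound 4. Starting from a value that is already a limit, compound 4 is therefore expected to give only a limit again, with an estimate of 300000 nM.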

Compound 4, half-maximal inhibitory concentration: > 100000 nM
Compound 4: only a limit was reported; the forecaster's own chance of this, stated with the estimate: 90%; the middle value is on the limit's open side.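

In this assay, compound 3 and compound 4 both give only a limit rather than a number, so no step between them can be read: the limit of > 100000 nM in this assay, at which 2 of the 4 values shown sit.

The compounds shown leave open whether nitro in place of hydrogen on an aromatic carbon changes the inhibition at all on the core of compound 3, as it does on the core of compound 1.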